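Cytotoxicity notes on the N-aryl pyrrole series

The compounds below may be only part of what the source reports. "The series", "measured", "known", "first", "only" and "open" are said of these compounds alone.

Measured so far in an ADME assay on L6 cells (Rattus norvegicus) for cytotoxicity, read by resazurin assay, with a stated time of 72 h; a higher number here means that more compound is needed for the effect, a lower number that less compound is needed:
compound 1 `CCOC(=O)C1=C(C)N/C(=C/c2cc(C)n(-c3cccc(OC)c3)c2C)C1=O` — 56000 nM
compound 2 `CCOC(=O)C1=C(C)N/C(=C/c2cc(C)n(-c3cccnc3)c2C)C1=O` — 160000 nM

Among the measured compounds shown here, compound 2 stands highest of the two numbers; its nearest neighbour is compound 1, and the only step recorded, a 2.9-fold higher number from compound 1 to compound 2 (0.46 log units; beyond the scatter), separates them. Compound 3 `CCOC(=O)C1=C(C)N/C(=C/c2cc(C)n(Cc3ccccc3)c2C)C1=O` differs from compound 2 by one change: benzyl in place of pyridin-3-yl on an aromatic nitrogen.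

For the measured compounds named here, only the step from compound 1 to compound 2 bears on this change, and then indirectly: it also swaps the group on the aromatic nitrogen, and it was modest. Going by the values given here, no step replaces a ring bound directly to the nitrogen with a benzyl, so the direction is uncertain. A modest shift is expected, most likely back toward the number of compound 1, but a step within the scatter cannot be excluded. For compound 3 in this assay the estimate is 75000 nM (25000 nM to 220000 nM), which corresponds to an expected step of a 2.1-fold lower number from compound 2 to compound 3 (0.33 log units; beyond the scatter).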

Compound 3, half-maximal effective concentration: 50000 nM
Compound 3: middle estimate off by 1.5-fold (0.18 log units), on the high side; measured number inside the range.
By their numbers in this assay, from the lowest: compounds 3 and 1 (each within the scatter of the next); then compound 2.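

In this assay, benzyl in place of pyridin-3-yl on the aromatic nitrogen gives a 3.2-fold lower number from compound 2 to compound 3 (0.51 log units; beyond the scatter), which shows that the higher number of compound 2 does not carry over to this group. Benzyl in place of 3-methoxyphenyl gives a 1.1-fold lower number from compound 1 to compound 3 (0.05 log units; within the scatter), so these two groups cannot be told apart here, although only 3-methoxyphenyl has its ring bound directly to the nitrogen, and pyridin-3-yl, the only one of the three with a ring hetero atom, stands alone at the highest number. Nothing available accounts for this gap.

Going by these compounds, it remains open whether the higher number follows the ring nitrogen itself, as a pyridin-3-ylmethyl group would test. Also open, on these data alone, is how an amine or carboxylic acid on the ring, or a longer chain on the aromatic nitrogen, would move the number.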